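A few compounds are considered here, and "the series" means these few. Any claim that something is new, unique, unknown or untested is made for them only; others in the source may bear on it.

Of the compounds shown here, three sharing one core have been measured in an assay on HL-60 cells for agonist activity at vitamin D3 receptor (Homo sapiens), read by microscopy, with a stated time of 96 h; a higher number here means that more compound is needed for the effect, a lower number that less compound is needed. Compound 1 `CC[C@@H](C)[C@H](NC(=O)c1ccc(C(CC)(CC)c2ccc(OCC(O)C(C)(C)C)c(C)c2)n1CC)C(=O)OC` gives 26 nM; compound 2 `CCn1c(C(=O)N(C)CCC#N)ccc1C(CC)(CC)c1ccc(OCC(O)C(C)(C)C)c(C)c1` gives 1960 nM; compound 3 `C#CCCOC(=O)c1ccc(C(CC)(CC)c2ccc(OCC(O)C(C)(C)C)c(C)c2)n1CC` gives 1030 nM. Compound 3 thus stands second highest of the three numbers: the gap a 1.9-fold lower number from compound 2 to compound 3 (0.28 log units; within the scatter) is within the scatter, whereas the gap a 40-fold higher number from compound 1 to compound 3 (1.60 log units; beyond the scatter) is large. Compound 4 `CCOC(=O)c1ccc(OC(=O)c2ccc(C(CC)(CC)c3ccc(OCC(O)C(C)(C)C)c(C)c3)n2CC)cc1` is the next compound, and it differs from compound 3 by 4-(ethoxycarbonyl)phenyl in place of but-3-yn-1-yl on an oxygen next to a carbonyl group. Every measured step here varies the group on the carbonyl carbon, so all three bear on it. The step of a 1.9-fold lower number from compound 2 to compound 3 (0.28 log units; within the scatter) shows that exchanging one small ester or amide group for another leaves the number where it was, while the steps of a 75-fold higher number from compound 1 to compound 2 (1.88 log units; beyond the scatter) and a 40-fold higher number from compound 1 to compound 3 (1.60 log units; beyond the scatter) show that the group carried on that carbonyl can move the number a long way. Compound 4 carries a larger group with 2 hydrogen-bond acceptors, so a moderately lower number is expected, estimated at 450 nM, within 100 nM to 2500 nM. For compound 4 that means an expected step of a 2.3-fold lower number from compound 3 to compound 4 (0.36 log units; beyond the scatter).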

Compound 4, half-maximal effective concentration: > 50000 nM
Compound 4 gave a limit, no number; the forecaster's own chance of this, stated with the estimate: 5%; at least 110-fold (2.04 log units) between middle value and limit.
By their numbers in this assay, from the lowest: compound 1; then compounds 3 and 2 (each within the scatter of the next). At a limit, above all of these: compound 4.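

In this assay compound 4 gives a limit and not a number: the limit of > 50000 nM in this assay, at which 1 of the 4 values shown sits. Set against that limit, the exchange on the oxygen next to the carbonyl group gives an at least 48-fold higher number from compound 3 to compound 4 (1.68 log units; beyond the scatter), and the same limit gives an at least 25-fold higher number from compound 2 to compound 4 (1.40 log units; beyond the scatter) and an at least 1900-fold higher number from compound 1 to compound 4 (3.28 log units; beyond the scatter), all of them large. Compounds 2 and 3 had shown a change on this carbonyl that left the number in place, whereas compound 4 shows that, among esters at this position, the group on the oxygen alone can move the number upward by a large step.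

The compounds shown do not separate the aromatic ring of 4-(ethoxycarbonyl)phenyl from its ethoxycarbonyl group. A plain phenyl ester, or a carboxylic acid in place of the ethoxycarbonyl, would address that question.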